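The source may report more compounds than this note shows. Statements on the series, on what has been measured and on what is new or still open speak of the compounds shown alone.

Compounds measured in a functional assay on MCF7 cells (Homo sapiens) for cytotoxicity, read by MTT assay, with a stated time of 24 h; on this read-out lower numbers stand for stronger inhibition and higher numbers for weaker inhibition:
compound 1 `O=C(CN1CCN(c2ccccc2)CC1)N1CCN(c2nnc(-c3ccccc3)c(-c3ccccc3)n2)CC1` gives > 963000 nM, a limit of this assay.
compound 2 `COc1ccc(N2CCN(CC(=O)N3CCN(c4nnc(-c5ccccc5)c(-c5ccccc5)n4)CC3)CC2)cc1` gives > 910000 nM, again only a limit.
compound 3 `O=C(CN1CCN(c2ccccc2)CC1)N1CCN(c2nnc(-c3ccc(Cl)cc3)c(-c3ccc(Cl)cc3)n2)CC1` gives > 850000 nM, also a limit.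

All three values sit at limits, so none of the three can be ordered against another. From compound 1 to compound 2 the change is methoxy in place of hydrogen on an aromatic carbon; the step that the two limits leave unreadable from compound 1 to compound 2 cannot be read because both ends are limits the limit of > 963000 nM in this assay, at which 1 of the 3 values shown sits (the limit of > 910000 nM in this assay, at which 1 of the 3 values shown sits). The difference between the core of compound 1 and the core of compound 3 is not broken down here.

Compound 4 `COc1ccccc1N1CCN(CC(=O)N2CCN(c3nnc(-c4ccc(Cl)cc4)c(-c4ccc(Cl)cc4)n3)CC2)CC1` is not yet measured. It differs from compound 3 by methoxy in place of hydrogen on an aromatic carbon, the same kind of change as that from compound 1 to compound 2, but the place differs: in compound 4 the methoxy stands ortho to a large group, in compound 2 para to a large group.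

For compound 4 in this assay the expectation rests on compound 3, whose result > 850000 nM is a limit (the limit of > 850000 nM in this assay, at which 1 of the 3 values shown sits), and on compound 2, whose result is likewise a limit (the limit of > 910000 nM in this assay, at which 1 of the 3 values shown sits). The step from compound 3 to compound 4 is therefore expected to be a number no higher from compound 3 to compound 4 (the limit leaves the size open), most likely unreadable. Compound 4 is estimated at 850000 nM, between 300000 nM and 2000000 nM.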

Compound 4, half-maximal inhibitory concentration: 330000 nM
Beside the measured number, compound 4's estimate is 2.6-fold (0.41 log units) above it, within the range that was stated.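

In this assay, methoxy in place of hydrogen on an aromatic carbon, ortho to a large group, gives an at least 2.5-fold lower number from compound 3 to compound 4 (0.41 log units; beyond the scatter), and the size is only a minimum, as the starting point is a limit: the limit of > 850000 nM in this assay, at which 1 of the 4 values shown sits.

On the core of compound 1 the same kind of change, with the methoxy at a different place on the ring, leads to compound 2, but that step cannot be read: both of its ends are limits. The change therefore has a readable effect on one core only, and nothing here shows that it carries to the other core, nor can the contribution of the core be separated from that of the place on the ring.

Still open, on these data alone, is what phenyl to 2-methoxyphenyl does on the core of compound 1, which would put core and place on an equal footing. Also open, as far as these compounds go, is whether an amine, a hydroxyl or a carboxylic acid at the same place on the ring would act as methoxy does in compound 4.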